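This account rests on a few compounds, and the source may have more. Where it says the series, first, only, none or still open, it means among the compounds named here.

Compound 2 `c1csc(-c2cn3ccnc3c(-c3ccc4ncn(C5CCCCC5)c4c3)n2)c1` and compound 1 `c1cn2cc(-c3ccsc3)nc(-c3ccc4ncn(C5CCCCC5)c4c3)c2n1` share one core and differ only in how a thiophene ring is attached. In a functional assay on HT-29 cells (Homo sapiens) for inhibition, read by sulforhodamine B assay, with a stated time of 48 h, tested at 10 uM (a lower number here means less inhibition, a higher number more inhibition at the concentration tested (going by the name of the read-out)), compound 2 gives 0.09%, the lowest of the two numbers, while compound 1 gives 5.68%; the step of a number 5.6 percentage points lower from compound 1 to compound 2 (within the scatter) lies within the scatter, so neither compound shows any clear inhibition at the concentration tested. Compound 3 `FC(F)(F)c1cccc(-c2cn3ccnc3c(-c3ccc4ncn(C5CCCCC5)c4c3)n2)c1` differs from compound 2 by 3-(trifluoromethyl)phenyl in place of thiophen-2-yl on an aromatic carbon. Going by the values given here, the one measured step, a number 5.6 percentage points lower from compound 1 to compound 2 (within the scatter), swaps one thiophene for another and says little about a change to 3-(trifluoromethyl)phenyl; both measured compounds sit near zero, and nothing seen so far points to a gain. For compound 3 the expected step of a number 4.9 percentage points higher from compound 2 to compound 3 (within the scatter) is therefore small, with its direction left open. Compound 3 is estimated at 5% in this assay, within a range of -5% to 25%.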

Compound 3, a percentage reported as inhibition, at one concentration (the size of the read-out at that concentration, not a potency): 6.41%
Compound 3: middle estimate off by 1.4 percentage points, on the low side, within the range that was stated.
By their numbers in this assay, from the lowest: compounds 2, 1 and 3 (each within the scatter of the next).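

Putting 3-(trifluoromethyl)phenyl in place of thiophen-2-yl gives a number 6.3 percentage points higher from compound 2 to compound 3 (within the scatter) in this assay, and putting it in place of thiophen-3-yl gives a number 0.7 percentage points higher from compound 1 to compound 3 (within the scatter) in the same test. The earlier pair compared only two ways of attaching a thiophene, whereas this aromatic carbon now also carries a six-membered aromatic ring of carbon only, and the three compounds cannot be told apart, none showing clear inhibition at the concentration tested. Nothing available explains this flat result.

These compounds leave open whether a group of another kind on this carbon, such as an amine or a carboxylic acid, would give a clear reading. They also leave open whether changing the cyclohexyl group elsewhere on the shared core would do so.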